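Aryl amide swap on a coumarin-furoxan hybrid scaffold

A few compounds are considered here, and "the series" means these few. Any claim that something is new, unique, unknown or untested is made for them only; others in the source may bear on it.

The measured compounds and their values in a functional assay on MCF7 cells (Homo sapiens) for inhibition, read by MTT assay, with a stated time of 48 h (a higher number here means a weaker inhibitor, a lower number a stronger inhibitor), are:
- compound 1, `COc1cc2cc(C(=O)NCc3ccc(F)cc3)c(=O)oc2cc1OCCCOc1no[n+]([O-])c1S(=O)(=O)c1ccccc1`, 370 nM
- compound 2, `COc1cc2cc(C(=O)Nc3ccccc3)c(=O)oc2cc1OCCCOc1no[n+]([O-])c1S(=O)(=O)c1ccccc1`, 740 nM
- compound 3, `COc1cc2cc(C(=O)NCCCc3ccccc3)c(=O)oc2cc1OCCCOc1no[n+]([O-])c1S(=O)(=O)c1ccccc1`, 870 nM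

Compound 3 carries the highest number of the three. Its gap to compound 2 is small: a 1.2-fold higher number from compound 2 to compound 3 (0.07 log units; within the scatter). Against compound 1 the gap is larger: a 2.4-fold higher number from compound 1 to compound 3 (0.37 log units; beyond the scatter). Compound 1 and compound 2 sit close to each other as well: a 2.0-fold higher number from compound 1 to compound 2 (0.30 log units; within the scatter).

Compound 4, `COc1ccc(NC(=O)c2cc3cc(OC)c(OCCCOc4no[n+]([O-])c4S(=O)(=O)c4ccccc4)cc3oc2=O)cc1`, has not yet been measured. It differs from compound 3 in one place: 4-methoxyphenyl in place of 3-phenylpropyl on an amide-type nitrogen. Among the compounds with values here, only one measured step is truly comparable, the move from phenyl to 3-phenylpropyl, a 1.2-fold higher number from compound 2 to compound 3 (0.07 log units; within the scatter), which stayed within the scatter. Returning to an aromatic group directly on the amide nitrogen, now bearing a methoxy group, is therefore expected to give at most a modest step, if any, in this assay, and the direction is uncertain; a step toward a lower number is expected, a 1.5-fold lower number from compound 3 to compound 4 (0.16 log units; within the scatter).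

Compound 4 is estimated at 600 nM, with a range from 250 nM to 1500 nM.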

Compound 4, half-maximal inhibitory concentration: 410 nM
For compound 4 the middle estimate is 1.5-fold (0.17 log units) above the measured one, within the range that was stated.
By their numbers in this assay, from the lowest: compounds 1, 4, 2 and 3 (each within the scatter of the next, the first and the last beyond it).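

In this assay, within the data shown here, the amide nitrogen responds to this swap by more than the scatter: 4-methoxyphenyl in place of 3-phenylpropyl gives the first step at this position to compound 3 that clears it in this direction (a 2.1-fold lower number from compound 3 to compound 4 (0.33 log units; beyond the scatter)). Methoxy in place of hydrogen on an aromatic carbon stays within the scatter (a 1.8-fold lower number from compound 2 to compound 4 (0.26 log units; within the scatter)), and so does 4-methoxyphenyl in place of 4-fluorobenzyl (a 1.1-fold higher number from compound 1 to compound 4 (0.04 log units; within the scatter)), so neither pair can be ranked. No measurement here accounts for these steps.

The compounds shown leave open how a 4-methoxybenzyl group on the amide nitrogen would compare with 4-fluorobenzyl and 4-methoxyphenyl. They also leave open what an amine or a carboxylic acid in place of the methoxy would do in this assay.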